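This account rests on a few compounds, and the source may have more. Where it says the series, first, only, none or still open, it means among the compounds named here.

Compound 1 `Cc1c(-c2cc(Cl)cc(Cl)c2)c(C(=O)O)nn1-c1nc(-c2cc(Cl)ccc2F)c(SC(C)C)s1`: 4800 nM
Compound 2 `Cc1nn(-c2nc(-c3ccc(Cl)c(Cl)c3)c(SC(C)C)s2)c(C(=O)O)c1-c1cncc(C#N)c1`: 20000 nM
Compound 3 `Cc1c(-c2cc(Cl)cc(Cl)c2)c(C(=O)O)nn1-c1nc(-c2cc(Cl)cc(Cl)c2)c(SC(C)C)s1`: 2000 nM

In a functional assay on BJAB cells (Homo sapiens) for antiproliferative activity, with a stated time of 4 days (a higher number here means that more compound is needed for the effect, a lower number that less compound is needed), compound 2 stands highest of the three numbers, beyond the scatter from both compound 1 and compound 3, so it needs the most compound of the set. Compound 4 `COc1cccc(-c2c(C)nn(-c3nc(-c4ccc(Cl)c(Cl)c4)c(SC(C)C)s3)c2C(=O)O)c1` is not yet measured. It differs from compound 2 in one place: 3-methoxyphenyl in place of 5-cyanopyridin-3-yl on an aromatic carbon. Among the compounds with values here, the only measured single step, a 2.4-fold lower number from compound 1 to compound 3 (0.38 log units; beyond the scatter), changes a different ring and so does not bear directly on this change. Compound 1 and compound 3, which carry a carbon-only aromatic ring at this place, both give lower numbers than compound 2, but they also differ elsewhere. A modest step to a lower number is therefore expected, with wide uncertainty. Compound 4 is estimated at 7000 nM, between 2500 nM and 20000 nM, meaning an expected 2.9-fold lower number from compound 2 to compound 4 (0.46 log units; beyond the scatter).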

Compound 4, half-maximal effective concentration: 14000 nM
Compound 4: the middle estimate sits 2.0-fold (0.30 log units) below what was measured, within the range that was stated.
By their numbers in this assay, from the lowest: compound 3; then compound 1; then compounds 4 and 2 (each within the scatter of the next).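

In this assay, putting 3-methoxyphenyl in place of 5-cyanopyridin-3-yl gives a 1.4-fold lower number from compound 2 to compound 4 (0.15 log units; within the scatter) and so stays within the scatter. On this aromatic carbon, compound 2 and compound 4 therefore cannot be told apart, even though the nitrile and the ring nitrogen are gone. Nothing measured here explains this result.

Still open, as far as these compounds go, is whether an unsubstituted phenyl ring, an amine or a longer chain on this carbon would move the number beyond the scatter. Also open, from the compounds shown here alone, is how 3,5-dichlorophenyl here compares with 3-methoxyphenyl when all else is equal.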